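Working notes: shortening the chain on the core of compound 2

The compounds below may be only part of what the source reports. "The series", "measured", "known", "first", "only" and "open" are said of these compounds alone.

Measured so far, in this assay (concentration for half-maximal effect):
compound 1 `O=c1cc(Nc2ccccc2)cc(-c2ccccc2)o1`: 0.13 uM
compound 2 `CCCCCc1cc(Nc2ccc(OC)cc2)cc(=O)o1`: 10.1 uM
compound 3 `COc1ccccc1Nc1cc(-c2ccccc2)oc(=O)c1`: 0.35 uM

In a functional assay on KB cells (Homo sapiens) for cytotoxicity, read by MTT assay, with a stated time of 72 h (on this read-out higher numbers stand for an effect only at larger amounts of compound and lower numbers for an effect already at smaller amounts), compound 2 gives 10.1 uM, the highest number of the three; its gaps to compound 3 and to compound 1 both lie beyond the scatter, so compound 2 is the weakest of the measured set. Among the measured compounds shown here, the only single-point step available, a 2.7-fold higher number from compound 1 to compound 3 (0.43 log units; beyond the scatter), concerns methoxy on the aniline ring and says nothing about the group on the core. Compounds 1 and 3 carry phenyl where compound 2 carries pentyl, but they also differ from compound 2 in the methoxy, so their values only show that both lie well below compound 2.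

Compound 4 `COc1ccc(Nc2cc(C(C)C)oc(=O)c2)cc1` differs from compound 2 by isopropyl in place of pentyl on an aromatic carbon. For the measured compounds named here, no measured step bears on this change. The expectation for compound 4 is therefore a number close to compound 2, with no step beyond the scatter claimed in either direction, and a wide range: estimate 8 uM (2 uM to 30 uM), that is a 1.3-fold lower number from compound 2 to compound 4 (0.10 log units; within the scatter).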

Compound 4, concentration for half-maximal effect: > 30 uM
Compound 4: a limit, no number; the forecaster's own chance of this, stated with the estimate: 5%; middle value at least 3.7-fold (0.57 log units) away from the limit.
By their numbers in this assay, from the lowest: compound 1; then compound 3; then compound 2. At a limit, above all of these: compound 4.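

In this assay compound 4 gives > 30 uM, which is a limit of the assay and not a number. Among the compounds shown here, this is the first reading for a change made only at the aromatic carbon next to the ring oxygen, and isopropyl in place of pentyl there gives an at least 2.9-fold higher number from compound 2 to compound 4 (0.47 log units; beyond the scatter). The group at this position therefore affects the read-out, although the pair shows only one direction and no upper end to the step: the limit of > 30 uM in this assay, at which 1 of the 4 values shown sits.

From the compounds shown here alone, it remains open whether a chain longer than pentyl, or an amine at the end of the pentyl chain, would move the number in the opposite direction. Also open, going by these compounds, is what phenyl at this position does on its own, with the methoxy kept as in compound 2.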